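A Ring Returns to the Amide of Compound 2

The source may hold more compounds than are shown below. What is called first, only, known or untested is meant among the compounds shown, and "the series" means these compounds.

Of the compounds shown here, two sharing one core have been measured in an assay on HEK293 cells for displacement of a labelled ligand from NPC1-like intracellular cholesterol transporter 1 (Homo sapiens); on this read-out higher numbers stand for weaker inhibition and lower numbers for stronger inhibition. Compound 1 `CC(C)(C)c1ccc(C(=O)N2CCC3(CC2)C(=O)N(CC(=O)N2CCN(S(C)(=O)=O)CC2)CN3c2ccccc2)cc1` gives 19000 nM. Going by the values given here, compound 2 `CC(C)(C)c1ccc(C(=O)N2CCC3(CC2)C(=O)N(CC(=O)NCCN)CN3c2ccccc2)cc1` gives 7000 nM, the lowest of the two numbers, and the only known step, a 2.7-fold lower number from compound 1 to compound 2 (0.43 log units; beyond the scatter), separates them. Compound 3 `CC(C)(C)c1ccc(C(=O)N2CCC3(CC2)C(=O)N(CC(=O)N2CCCC(CO)C2)CN3c2ccccc2)cc1` differs from compound 2 in one place: 3-(hydroxymethyl)piperidin-1-yl in place of (2-aminoethyl)amino on a carbonyl carbon. This removes the open chain of compound 2 and puts a ring back on the carbonyl carbon, which mirrors, in reverse, the change between compound 1 and compound 2, where a ring gave way to the open chain. That single modest step is all that bears on the question, and the entering ring of compound 3 lacks the sulfonyl group of compound 1, so it is only a rough guide. A modest move toward higher numbers is therefore expected, a 1.7-fold higher number from compound 2 to compound 3 (0.23 log units; within the scatter). For compound 3 the estimate in this assay is 12000 nM, with a range from 5000 nM to 30000 nM.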

Compound 3, half-maximal inhibitory concentration: 8200 nM
Beside the measured number, compound 3's estimate is 1.5-fold (0.17 log units) above it, and the stated range covers the measured number.
By their numbers in this assay, from the lowest: compounds 2 and 3 (each within the scatter of the next); then compound 1.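

In this assay, replacing the open (2-aminoethyl)amino chain on the carbonyl carbon with the 3-(hydroxymethyl)piperidin-1-yl ring gives a 1.2-fold higher number from compound 2 to compound 3 (0.07 log units; within the scatter) and so shows that, for these two groups, a ring and an open chain at this place cannot be told apart, even though 8 heavy atoms enter where 4 leave. Comparing ring with ring, 3-(hydroxymethyl)piperidin-1-yl in place of 4-(methylsulfonyl)piperazin-1-yl gives a 2.3-fold lower number from compound 1 to compound 3 (0.36 log units; beyond the scatter) and so shows that the weaker result of compound 1 goes with that particular ring, not with having a ring at all. Nothing available here explains either result.

As far as these compounds go, whether the hydroxymethyl group matters remains open, and a plain piperidin-1-yl group on the same carbonyl carbon would test this. From the compounds shown here alone, it is also open whether a carboxylic acid on a longer chain would give a clearly different number here.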